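Amino in place of hydroxy: what to expect

The source may report more compounds than this note shows. Statements on the series, on what has been measured and on what is new or still open speak of the compounds shown alone.

compound 1 `COc1ccc(C(=O)c2ccc(OC)c3c2OC(C)(C)C=C3)c(NC(=O)CBr)c1` gives 2360 nM
compound 2 `COc1ccc(C(=O)c2ccc(OC)c3c2OC(C)(C)C=C3)c(NC(=O)CO)c1` gives 320 nM
compound 3 `COc1ccc(C(=O)c2ccc(OC)c3c2C=CC(C)(C)O3)c(NC(=O)CO)c1` gives 940 nM

These values come from a functional assay on MCF7 cells (Homo sapiens) for antiproliferative activity, read by MTT assay, with a stated time of 48 h (on this read-out lower numbers stand for stronger inhibition and higher numbers for weaker inhibition), and compound 2 at 320 nM has the lowest number of the three, with the other two higher by more than the usual scatter. The next compound is compound 4 `COc1ccc(C(=O)c2ccc(OC)c3c2OC(C)(C)C=C3)c(NC(=O)CN)c1` which has amino in place of hydroxy on a saturated chain carbon bound to a carbonyl carbon. Within the data shown here, only one measured step involves this place. It is a 7.4-fold lower number from compound 1 to compound 2 (0.87 log units; beyond the scatter) when hydroxy replaced bromo, a modest change but beyond the scatter. So a swap on this carbon can move the number. Compound 3 keeps the hydroxy but has a different core, so it says nothing direct about this swap. Among the measured compounds shown here, no compound with amino here has been measured, so the size of the step remains a judgement. A smaller step than the bromo to hydroxy one is expected. A somewhat higher number seems more likely than a lower one because compound 2 gives 320 nM and that is already the lowest value seen. The expected change is a 1.4-fold higher number from compound 2 to compound 4 (0.15 log units; within the scatter) and it remains an estimate. For compound 4 the estimated value is 450 nM (expected range 150 nM to 1500 nM).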

Compound 4, half-maximal inhibitory concentration: 410 nM
The estimate for compound 4 lay 1.1-fold (0.04 log units) above the measured number; the range from low to high includes it.
By their numbers in this assay, from the lowest: compounds 2 and 4 (each within the scatter of the next); then compound 3; then compound 1.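

In this assay the swap of hydroxy for amino on this saturated chain carbon bound to a carbonyl carbon gives a 1.3-fold higher number from compound 2 to compound 4 (0.11 log units; within the scatter) and so does not separate the two groups, which means that this particular change of oxygen for nitrogen leaves the number where it was within ordinary repeat variation. The other new comparison gives a 5.8-fold lower number from compound 1 to compound 4 (0.76 log units; beyond the scatter) and shows that the earlier drop on leaving bromo is no longer tied to hydroxy alone, since amino at the same place also stands clearly apart from bromo. The compounds shown come with no separate measurement that could explain this shared behaviour of hydroxy and amino.

Still open, as far as these compounds go, is whether larger or differently charged groups at this carbon, such as dimethylamino, a carboxylic acid or a longer chain ending in amino, would stay close to compound 2 or move away from it. Also open, from the compounds shown here alone, is whether amino on the core of compound 3 would match hydroxy there as it does on the core of compound 2.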